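Swapping a saturated ring for pyridin-3-yl on the carbonyl

The compounds below may be only part of what the source reports. "The series", "measured", "known", "first", "only" and "open" are said of these compounds alone.

Measured so far:
compound 1 `O=C(C1CCN(c2ccncn2)CC1)N1N=CC[C@H]1c1ccccc1` — 3.2
compound 2 `O=C(C1CCCCC1)N1N=CCC1c1ccccc1` — 5.9

Both compounds were measured in a physicochemical assay for lipophilicity, read by HPLC, measured as chromatographic lipophilicity, at pH 7.4; on this read-out lower numbers stand for lower lipophilicity and higher numbers for higher lipophilicity. In this assay compound 2 gives 5.9, the higher of the two numbers. Compound 1 gives 3.2, a gap beyond the scatter of repeated measurements, so the two compounds are clearly apart on this read-out.

Compound 3 `O=C(c1cccnc1)N1N=CCC1c1ccccc1` has not yet been measured. It shares the core of compound 2 and differs in one place: pyridin-3-yl in place of cyclohexyl on a carbonyl carbon. The change sits on a carbonyl carbon whose other neighbour is an amide-type nitrogen in a ring.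

Among the measured compounds shown here, no step between two measured compounds that differ in one place is available, so the size of this change cannot be read off directly. Compound 1, which carries a different group at the same carbonyl, gives 3.2, well under the value of compound 2, and compound 3 is expected to land between these two numbers rather than at either end. For compound 3 the expected value in this assay is 3.6, within a range from 2.9 to 4.3. This estimate means a step of a number 2.30 log units lower from compound 2 to compound 3 (beyond the scatter), a decrease beyond the scatter.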

Compound 3, distribution coefficient: 2.7
Beside the measured number, compound 3's estimate is 0.90 log units above it; the whole stated range lies above it.
By their numbers in this assay, from the lowest: compound 3; then compound 1; then compound 2.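

In this assay, among the compounds shown here, the swap of cyclohexyl for pyridin-3-yl on a carbonyl carbon whose other neighbour is an amide-type nitrogen in a ring gives a number 3.20 log units lower from compound 2 to compound 3 (beyond the scatter) and this is the first step at this position that can be read directly. The size of the ring and its count of heavy atoms stay the same, so a step this large comes with a change in ring type alone: an aromatic ring with one nitrogen and one hydrogen-bond acceptor replaces a non-aromatic ring of carbon only. No measurement at hand accounts for the size of this step.

A phenyl group on the same carbonyl carbon would help separate what goes with the aromatic ring from what goes with its nitrogen, and pyridin-2-yl or pyridin-4-yl would show whether the place of that nitrogen matters. The compounds shown also leave open how a ring carrying an amine or a carboxylic acid would read here, and whether this step keeps its size on a different core.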